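From oxan-3-yl to 3-methylfuran-2-yl on a carbonyl carbon

The compounds below may be only part of what the source reports. "The series", "measured", "known", "first", "only" and "open" are said of these compounds alone.

Measured so far in a physicochemical assay for solubility, read by mass spectrometry, in phosphate buffer, with a stated time of 24 h, at pH 7.4 (on this read-out higher numbers stand for higher solubility and lower numbers for lower solubility), are these compounds:

- compound 1 `O=C(Nc1ccc(C(F)(F)F)cc1)NC1CCN(C(=O)C2CCCOC2)CC1` with 1.1 ug/mL as its value
- compound 2 `O=C(Nc1ccc(OC(F)(F)F)c(F)c1)NC1CCN(C(=O)C2(C(F)(F)F)CC2)CC1` with 92 ug/mL as its value
- compound 3 `CC[C@H](C)C(=O)N1CCC(CC(=O)Nc2ccc(OC(F)(F)F)c(F)c2)CC1` with 21 ug/mL as its value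

Compound 1 (1.1 ug/mL) stands lowest of the three in this assay and beyond the scatter of both others, with compound 3 (21 ug/mL) the nearer and compound 2 (92 ug/mL) the further.

Compound 4 `Cc1ccoc1C(=O)N1CCC(NC(=O)Nc2ccc(C(F)(F)F)cc2)CC1` has not yet been measured. It keeps the rest of compound 1 and carries 3-methylfuran-2-yl in place of oxan-3-yl on a carbonyl carbon. Going by the values given here, no two measured compounds differ in one place only, so the data hold no direct measure of such a change. Compound 2 and compound 3 each differ from compound 1 in more than one place, so their higher values say little about this swap.

The expectation therefore starts from compound 1 (1.1 ug/mL), and no step beyond the scatter is expected in this assay for this change. The estimated step runs (a 1.5-fold higher number from compound 1 to compound 4 (0.16 log units; within the scatter)) and stays small. For compound 4 the estimated value is 1.6 ug/mL (expected range 0.5 ug/mL to 7 ug/mL).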

Compound 4, solubility: 0.8 ug/mL
Compound 4: the middle estimate sits 2.0-fold (0.30 log units) above what was measured, and the stated range covers the measured number.
By their numbers in this assay, from the lowest: compounds 4 and 1 (each within the scatter of the next); then compound 3; then compound 2.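

In this assay, going by these compounds alone, the exchange of oxan-3-yl for 3-methylfuran-2-yl on a carbonyl carbon now has a direct reading (a 1.4-fold lower number from compound 1 to compound 4 (0.14 log units; within the scatter)), which the earlier compounds, each differing from compound 1 in more than one place, could not give. The two groups match in their count of heavy atoms, each with one oxygen and one hydrogen-bond acceptor, yet a six-membered non-aromatic ring gives way to a five-membered aromatic ring, and in this one pair the two values still stand within the scatter of each other. No supporting data bear on this result.

The compounds shown leave open whether a group of another kind on this carbonyl carbon, such as a ring carrying an amine or a carboxylic acid, would give a step beyond the scatter in this assay, given that both groups compared here carry no net charge. They also leave open whether the same exchange would read alike on a core other than that of compound 1.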